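This account rests on a few compounds, and the source may have more. Where it says the series, first, only, none or still open, it means among the compounds named here.

Of the compounds shown here, three share one core and have been tested so far. Compound 1 `COc1ccc(C2=NN(C3=NC(c4ccccc4)CS3)C(c3cccc4ccccc34)C2)cc1` in a functional assay on HepG2 cells (Homo sapiens) for inhibition, read by CCK-8 assay, with a stated time of 48 h (a higher number here means a weaker inhibitor, a lower number a stronger inhibitor), gives 8740 nM. Compound 2 `c1ccc(C2=NN(C3=NC(c4ccccc4)CS3)C(c3cccc4ccccc34)C2)cc1` gives 13200 nM in this assay, and compound 3 `Cc1ccc(C2=NN(C3=NC(c4ccccc4)CS3)C(c3ccc4ccccc4c3)C2)cc1` gives 14700 nM there. Among these three numbers compound 2 holds the second highest, yet its value and those of compound 1 and compound 3 all sit within the scatter of one another, so no order among them can be read.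

Among the measured compounds shown here, the only step between two measured compounds that differ in a single place is a 1.5-fold higher number from compound 1 to compound 2 (0.18 log units; within the scatter), a change that stayed within the scatter. Compound 4 `Fc1ccc(C2=NN(C3=NC(c4ccccc4)CS3)C(c3cccc4ccccc34)C2)cc1` has not yet been measured. It differs from compound 2 in one place: fluoro in place of hydrogen on an aromatic carbon. The measured step bears on this in that it shows one exchange of a small group on an aromatic carbon of the shared core left the number essentially unchanged. For the measured compounds named here, no measured compound carries fluoro, so nothing shows what that group itself does here.

On the strength of that single step, no change beyond the scatter is expected from compound 2 to compound 4 in this assay, a 1.1-fold lower number from compound 2 to compound 4 (0.04 log units; within the scatter). The estimate for compound 4 is 12000 nM, with a range from 5000 nM to 30000 nM.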

Compound 4, half-maximal inhibitory concentration: 23200 nM
Compound 4: the middle estimate sits 1.9-fold (0.29 log units) below what was measured; measured number inside the range.
By their numbers in this assay, from the lowest: compounds 1, 2, 3 and 4 (each within the scatter of the next, the first and the last beyond it).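

At this place on the ring, para to a large group, fluoro in place of hydrogen gives a 1.8-fold higher number from compound 2 to compound 4 (0.24 log units; within the scatter) in this assay, so this exchange does not separate the two compounds. Fluoro in place of methoxy at the same place gives a 2.7-fold higher number from compound 1 to compound 4 (0.42 log units; beyond the scatter), a modest step but the first in this set to pass beyond the scatter, which shows that the number can respond to the group held here, even though compound 2 stays within the scatter of both compound 1 and compound 4. No accompanying measurement offers an explanation for this difference.

With only hydrogen, methoxy and fluoro shown at this place, it remains open whether an amine, a carboxylic acid or a longer chain would shift the number further, and in which direction. As far as these compounds go, it is also open whether fluoro in place of methoxy would give a similar step at other places on the shared core.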